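The source may hold more compounds than are shown below. What is called first, only, known or untested is meant among the compounds shown, and "the series" means these compounds.

Compound 1 `CCCc1nc(-c2ccccc2)c(CNCCCN2CCN(c3cccc(C)c3C)CC2)o1` gives 1780 nM, compound 2 `CCCc1nc(-c2ccccc2)c(CNCCN2CCN(c3ccccc3)CC2)o1` gives 10300 nM, and compound 3 `CCCc1nc(-c2ccccc2)c(CNCCCN2CCN(c3ccc(C)cc3)CC2)o1` gives 130000 nM, all in an assay on HEK293 cells for inhibition of Voltage-dependent T-type calcium channel subunit alpha-1G (Homo sapiens), read by patch clamp; on this read-out higher numbers stand for weaker inhibition and lower numbers for stronger inhibition.

On these numbers compound 2 stands second highest of the three, with compound 1 giving a lower number and compound 3 a higher one. Compound 4 `CCCc1nc(-c2ccccc2)c(CNCCN2CCN(c3ccc(C(F)(F)F)cc3)CC2)o1` differs from compound 2 by trifluoromethyl in place of hydrogen on an aromatic carbon. For the measured compounds named here, no measured step puts a trifluoromethyl group onto this ring. Going by the values given here, the one step that alters the ring, a 73-fold higher number from compound 1 to compound 3 (1.86 log units; beyond the scatter), exchanges two groups at once and starts from another compound, so it bears only loosely; it does show that a change of this ring can go with a much higher number. A step toward a higher number is therefore expected, a 1.6-fold higher number from compound 2 to compound 4 (0.19 log units; within the scatter), though it may stay within the scatter. Compound 4 is estimated at 16000 nM, between 4000 nM and 65000 nM.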

Compound 4, half-maximal inhibitory concentration: 1300 nM
Beside the measured number, compound 4's estimate is 12-fold (1.09 log units) above it; measured number below the stated range.
By their numbers in this assay, from the lowest: compounds 4 and 1 (each within the scatter of the next); then compound 2; then compound 3.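

The step of a 7.9-fold lower number from compound 2 to compound 4 (0.90 log units; beyond the scatter) shows that trifluoromethyl in place of hydrogen on this aromatic carbon, para to a large group, goes with stronger inhibition in this assay. The earlier compounds shown here showed only a change of this ring that went with a higher number, so this position can move the number either way. Nothing measured here gives a reason for this step.

On these data alone, whether a chlorine atom, a methoxy group or a nitrile at this place would go the same way stays open. So does whether trifluoromethyl would have the same effect on the chain of compound 3.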